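Adding one methoxy to compound 3

The source may report more compounds than this note shows. Statements on the series, on what has been measured and on what is new or still open speak of the compounds shown alone.

Values in a functional assay on FM3A cells (Mus musculus) for antiproliferative activity, with a stated time of 48 h (on this read-out lower numbers stand for stronger inhibition and higher numbers for weaker inhibition), are as follows
- Compound 1 `C=C(Br)C(=O)Nc1ccc(C(=O)/C=C/c2ccc(OC)c(OC)c2OC)cc1` gives 530 nM
- Compound 2 `COc1cccc(/C=C/C(=O)c2ccc(N)cc2)c1OC` gives 29000 nM
- Compound 3 `COc1ccc(/C=C/C(=O)c2ccc(N)cc2)c(OC)c1` gives 43000 nM

Compound 3, at 43000 nM, sits within the scatter of compound 2 and holds the highest number of the three only by that slim margin, far from compound 1 at 530 nM in this assay.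

Compound 4 `COc1ccc(/C=C/C(=O)c2ccc(N)cc2)c(OC)c1OC` differs from compound 3 by methoxy in place of hydrogen on an aromatic carbon, with methoxy in place of hydrogen on an aromatic carbon. Among the compounds with values here, no measured pair differs in one place alone, so this expectation rests on little. No step beyond the scatter is expected. The expected change is a 1.7-fold lower number from compound 3 to compound 4 (0.24 log units; within the scatter) and so stays within the scatter. Compound 4 is estimated at 25000 nM (range 8000 nM to 60000 nM) in this assay.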

Compound 4, half-maximal inhibitory concentration: 29000 nM
Compound 4: middle estimate off by 1.2-fold (0.06 log units), on the low side, within the range that was stated.
By their numbers in this assay, from the lowest: compound 1; then compounds 2, 4 and 3 (each within the scatter of the next).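

In this assay, methoxy in place of hydrogen ortho to two methoxy groups leaves the number within the scatter (a 1.5-fold lower number from compound 3 to compound 4 (0.17 log units; within the scatter)), and a methoxy in place of hydrogen at a different ring carbon does the same (no change at the digits printed from compound 2 to compound 4 (within the scatter)). The large step comes from the nitrogen instead, where hydrogen in place of (1-bromoethenyl)carbonyl gives a 55-fold higher number from compound 1 to compound 4 (1.74 log units; beyond the scatter) while the methoxy groups stay the same. Nothing available explains these steps.

From the compounds shown here alone, whether a chlorine or an amine on this ring carbon would move the number remains open. So does whether a plain acetyl on the nitrogen would give a number close to that of compound 1.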